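Benzyl to 2-hydroxyphenyl on the amide-type nitrogen

The source may report more compounds than this note shows. Statements on the series, on what has been measured and on what is new or still open speak of the compounds shown alone.

In a functional assay on PC-3 cells (Homo sapiens) for inhibition, read by MTT assay (on this read-out higher numbers stand for weaker inhibition of growth and lower numbers for stronger inhibition of growth), compound 1 `CC1=C(/C=C/C(C)=C/C=C/C(C)=C\C(=O)Nc2ccc(O)cc2)C(C)(C)CCC1n1ccnc1` gives 11700 nM and compound 2 `CC1=C(/C=C/C(C)=C/C=C/C(C)=C\C(=O)Nc2cccc(F)c2)C(C)(C)CCC1n1ccnc1` gives 5620 nM, a change of a 2.1-fold lower number from compound 1 to compound 2 (0.32 log units; beyond the scatter).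

Compound 3 `CC1=C(/C=C/C(C)=C/C=C/C(C)=C\C(=O)NCc2ccccc2)C(C)(C)CCC1n1ccnc1` reads > 100000 nM, which is a limit and not a number; it stands at the limit of > 100000 nM in this assay, at which 1 of the 3 values shown sits.

Compound 4 `CC1=C(/C=C/C(C)=C/C=C/C(C)=C\C(=O)Nc2ccccc2O)C(C)(C)CCC1n1ccnc1` carries 2-hydroxyphenyl in place of benzyl on an amide-type nitrogen.

The closest measured changes put benzyl in and run the opposite way: an at least 8.5-fold higher number from compound 1 to compound 3 (0.93 log units; beyond the scatter), and an at least 17-fold higher number from compound 2 to compound 3 (1.25 log units; beyond the scatter).

Reversing that direction, the expected change in this assay is large and downward, an at least 12-fold lower number from compound 3 to compound 4 (1.09 log units; beyond the scatter).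

Compound 4 is expected at 8000 nM, with an estimated range of 2500 nM to 30000 nM.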

Compound 4, concentration for 50% growth inhibition: 15500 nM
Estimate against measurement, compound 4: 1.9-fold (0.29 log units) below; the measured number falls inside the stated range.
By their numbers in this assay, from the lowest: compound 2; then compounds 1 and 4 (each within the scatter of the next). At a limit, above all of these: compound 3.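

In this assay, 2-hydroxyphenyl on the amide-type nitrogen gives a second hydroxyphenyl comparison with benzyl, an at least 6.4-fold lower number from compound 3 to compound 4 (0.80 log units; beyond the scatter). Compound 3 stands at a limit, not a number: the limit of > 100000 nM in this assay, at which 1 of the 4 values shown sits. The 2-hydroxyphenyl and 4-hydroxyphenyl groups are not separated, a 1.3-fold higher number from compound 1 to compound 4 (0.12 log units; within the scatter), whereas 3-fluorophenyl retains the lower number, a 2.8-fold higher number from compound 2 to compound 4 (0.44 log units; beyond the scatter).

Still open, on these data alone, is how 3-hydroxyphenyl would compare with the 2-hydroxyphenyl and 4-hydroxyphenyl groups. Also open, as far as these compounds go, is whether an aminophenyl or carboxyphenyl group on the same nitrogen would stay in the range of compound 1 and compound 4.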